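This account rests on a few compounds, and the source may have more. Where it says the series, first, only, none or still open, it means among the compounds named here.

Measured so far:
compound 1, `c1ccc(CNCC[C@H]2CCC[C@H](c3ccccc3)C2)cc1`, 46 nM
compound 2, `c1ccc(CNCC[C@@H]2CCC[C@H](c3ccccc3)C2)cc1`, 130 nM; 49 nM (2 entries)

In an assay on membranes from liver for displacement of a labelled ligand from Sigma intracellular receptor 2 (Rattus norvegicus), read by scintillation counting, with a stated time of 120 min (a lower number here means a stronger inhibitor, a higher number a weaker inhibitor), compound 1 gives 46 nM, the only number shown for it, with one further entry that has no single number. Compound 2 has several entries in this assay (the several entries of compound 2 in this assay, 130 nM; 49 nM (2 entries)), and the two compounds share every atom and bond, differing only in configuration as drawn (the fact that compounds 1 and 2 differ only in the configuration as drawn). Compound 3, `c1ccc(CNCC[C@H]2CCC[C@@H](c3ccccc3)C2)cc1`, is not yet measured. Compared with compound 1, (the two compounds have the same atoms and bonds and differ only in configuration as drawn: 1 of 2 stereo elements differ; a stereocentre at a saturated ring carbon is drawn S in compound 1 and R in compound 3). Among the compounds with values here, no step between two measured compounds is given, so the size of this change is read from compound 2: its values against compound 1 sit close to the scatter, due to the several entries of compound 2 in this assay, 130 nM; 49 nM (2 entries), with at most a modest shift toward weaker binding. A similar small step is expected for compound 3, a 1.6-fold higher number from compound 1 to compound 3 (0.21 log units; within the scatter), giving an estimated 75 nM, with a range from 25 nM to 220 nM.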

Compound 3, inhibition constant: 47 nM
Estimate against measurement, compound 3: 1.6-fold (0.20 log units) above, within the range that was stated.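

In this assay, within the data shown here, changing the drawn configuration at one saturated ring carbon gives a 1.0-fold higher number from compound 1 to compound 3 (0.01 log units; within the scatter), the first step here that can be read directly between two measured compounds. This step concerns configuration alone: the fact that compounds 1 and 3 differ only in the configuration as drawn. Until now the size of such a change could only be judged from compound 2, whose entries of 130 nM; 49 nM (2 entries) lie far enough apart to leave it unclear, whereas this direct comparison shows that the drawn configuration at this stereocentre makes no difference that can be told from the scatter.

On these data alone, whether that holds only for this set of groups stays open: a hydroxyl or a carboxylic acid added to the shared core could make configuration at this carbon matter. Also open, as far as these compounds go, is how these stereoisomers behave at any other receptor.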